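The compounds below may be only part of what the source reports. "The series", "measured", "known", "first", "only" and "open" are said of these compounds alone.

Measured so far: compound 1 `O=c1cc(/C=N\c2ccccc2O)c2c(OCc3ccccc3)cc(OCc3ccccc3)cc2o1` with 33100 nM in a functional assay, read by spectrophotometry, with a stated time of 5 min; on this read-out lower numbers stand for stronger inhibition and higher numbers for weaker inhibition; compound 2 `O=c1cc(/C=N\c2ccc(O)cc2)c2ccc(OCc3ccccc3)cc2o1` with 525000 nM in this assay.

Compound 1 stands at the lower of the two numbers; compound 2 sits well higher, beyond the scatter. Compound 3 `O=c1cc(/C=N\O)c2c(OCc3ccccc3)cc(OCc3ccccc3)cc2o1` differs from compound 1 by hydroxy in place of 2-hydroxyphenyl on a double-bonded nitrogen, leaving only the hydroxy on the double-bonded nitrogen. For the measured compounds named here, no measured pair shows this change, so its size is unknown from the series. A step toward a higher number in this assay is expected, a 1.8-fold higher number from compound 1 to compound 3 (0.26 log units; within the scatter), of modest size. Compound 3 is estimated at 60000 nM, with a range of 15000 nM to 250000 nM.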

Compound 3, half-maximal inhibitory concentration: > 2000000 nM
Compound 3: only a limit was reported; the forecaster's own chance of this, stated with the estimate: 15%; middle value at least 33-fold (1.52 log units) from the limit.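

For the compounds shown here, on the double-bonded nitrogen, the 2-hydroxyphenyl cannot be cut back to hydroxy without a large loss: this change gives an at least 60-fold higher number from compound 1 to compound 3 (1.78 log units; beyond the scatter), the first single-place step in this assay. Keeping a hydroxy on that nitrogen is therefore not enough to retain the inhibition seen with compound 1. The reading for compound 3 is a limit of the assay and not a number: the limit of > 2000000 nM in this assay, at which 1 of the 3 values shown sits.

On these data alone, how much of the step belongs to the aromatic ring and how much to the hydroxy on it remains open. Also open, as far as these compounds go, is what a plain phenyl, an amine or a longer chain would give on the double-bonded nitrogen.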